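The source may hold more compounds than are shown below. What is called first, only, known or untested is meant among the compounds shown, and "the series" means these compounds.

Of the compounds shown here, three of a shared core have been measured in a functional assay on ACHN cells (Homo sapiens) for cytotoxicity, read by sulforhodamine B assay, with a stated time of 72 h; a higher number here means a weaker inhibitor of growth, a lower number a stronger inhibitor of growth. Compound 1 `O=C(Nc1ccccc1C(F)(F)F)C1CCc2ccccc2N1C(=O)c1ccccc1` gives 8090 nM in this assay. Compound 2 `COc1ccc(NC(=O)C2CCc3ccccc3N2)cc1` gives 38000 nM in this assay, and compound 3 `CCCCCCCCC(=O)N1c2ccccc2CCC1C(=O)Nc1ccccc1O` gives 65000 nM in this assay. Among these three numbers, compound 2 stands second highest: its value sits within the scatter of compound 3, while compound 1 shows a lower number, a gap that lies beyond the scatter. Going by the values given here, no two measured compounds differ in only one place, so no single step has been measured.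

Compound 4 `O=C(Nc1ccc(C(F)(F)F)cc1)C1CCc2ccccc2N1` has not yet been measured in this assay. It differs from compound 2 in one place: trifluoromethyl in place of methoxy on an aromatic carbon. Without a measured step of this kind in the set, the expected change from compound 2 is small; the estimated step is a 1.5-fold lower number from compound 2 to compound 4 (0.18 log units; within the scatter), with no clear direction beyond the scatter. Compound 4 is therefore expected to give about 25000 nM in this assay, within a range from 8000 nM to 80000 nM.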

Compound 4, concentration for 50% growth inhibition: 25000 nM
Compound 4: the middle estimate sits on the measured number at the digits printed; the range from low to high includes it.
By their numbers in this assay, from the lowest: compound 1; then compounds 4, 2 and 3 (each within the scatter of the next, the first and the last beyond it).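

In this assay, going by these compounds alone, the exchange of methoxy for trifluoromethyl on an aromatic carbon, para to a large group, gives the first single-place step in the set: a 1.5-fold lower number from compound 2 to compound 4 (0.18 log units; within the scatter). At this position, then, the two groups cannot be told apart in growth inhibition, even though the hydrogen-bond acceptor counted for methoxy is absent from trifluoromethyl and the entering group has more heavy atoms. No measurement shown here explains this result.

As far as these compounds go, whether an amine or a carboxylic acid on this same aromatic carbon would give a number beyond the scatter of compound 2 stays open. Also open, from the compounds shown here alone, is whether the same exchange would read alike on compounds carrying an acyl group on the nitrogen of the shared core.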